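The compounds below may be only part of what the source reports. "The series", "measured", "known", "first", "only" and "open" are said of these compounds alone.

Compound 1 `COC1=C(C)C(=O)C(CCCCCCCCCCn2cc(C[C@H](O)COCCOC[C@@H](O)Cc3ccc(-c4ccccc4)cc3)nn2)=C(C)C1=O` and compound 2 `COC1=C(OC)C(=O)C(CCCCCCn2cc(C[C@H](O)COCCOC[C@@H](O)Cc3ccc(-c4ccccc4)cc3)nn2)=C(C)C1=O` share a long chain carrying a larger head group, and both inhibit growth in a functional assay on HCT-116 cells (Homo sapiens) for inhibition, read by MTT assay, with a stated time of 72 h; a lower number here means a stronger inhibitor of growth, a higher number a weaker inhibitor of growth: compound 1 gives 4000 nM and compound 2 gives 5000 nM, two values that lie within the usual scatter of each other. Compound 3 `O[C@H](COCCOC[C@@H](O)Cc1cn(-c2cncnc2)nn1)Cc1ccc(-c2ccccc2)cc1` drops that chain and head and instead carries pyrimidin-5-yl on an aromatic nitrogen of the five-membered aromatic ring with three nitrogens. For compound 3 this assay reports only a limit, > 100000 nM, so no number is known for it. Compound 4 `O[C@H](COCCOC[C@@H](O)Cc1cn(-c2cncc3ccccc23)nn1)Cc1ccc(-c2ccccc2)cc1` differs from compound 3 in one place: isoquinolin-4-yl in place of pyrimidin-5-yl on an aromatic nitrogen — isoquinolin-4-yl in place of pyrimidin-5-yl on an aromatic nitrogen. Going by the values given here, with no measured step between these two to lean on, and with compound 3 sitting at the limit of the assay (the limit of > 100000 nM in this assay, at which 1 of the 3 values shown sits), the expected step of an at least 1.2-fold lower number from compound 3 to compound 4 (0.09 log units; that floor lies within the scatter) is none beyond the scatter, with only a modest chance of a measurable gain. Compound 4 is expected to give about 80000 nM, somewhere between 20000 nM and 300000 nM.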

Compound 4, concentration for 50% growth inhibition: 17800 nM
Estimate against measurement, compound 4: 4.5-fold (0.65 log units) above; measured number outside the range, below it.
By their numbers in this assay, from the lowest: compounds 1 and 2 (each within the scatter of the next); then compound 4. At a limit, above all of these: compound 3.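

In this assay, the group on an aromatic nitrogen of the five-membered ring with three nitrogens can move the result beyond the scatter: putting isoquinolin-4-yl in place of pyrimidin-5-yl gives an at least 5.6-fold lower number from compound 3 to compound 4 (0.74 log units; beyond the scatter). This is the only step shown at this position, and it also shows that a compound without the long chain and its head group can give a readable number: compound 4 gives 17800 nM. The step gives only a minimum size, because one of its ends is a limit and not a number: the limit of > 100000 nM in this assay, at which 1 of the 4 values shown sits.

The compounds shown leave open which part of the change matters, the added carbon-only ring or the ring nitrogen that leaves with pyrimidin-5-yl. A plain phenyl or a naphthalen-1-yl group at this position could help separate the two.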